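A few compounds are considered here, and "the series" means these few. Any claim that something is new, unique, unknown or untested is made for them only; others in the source may bear on it.

In a functional assay on HCT-116 cells (Homo sapiens) for antiproliferative activity, read by MTT assay, with a stated time of 72 h (on this read-out higher numbers stand for weaker inhibition and lower numbers for stronger inhibition), compound 3 (`NC1=NC2(CCSCC2)N(OCCCOc2ccccc2Cl)C(N)=N1`) gives 1 nM and stands level with compound 1 (`NC1=NC2(CCSCC2)N(OCCCOc2cccc(Cl)c2)C(N)=N1`) at 1 nM and compound 2 (`NC1=NC2(CCSCC2)N(OCCCOc2ccccc2Br)C(N)=N1`) at 1 nM on these numbers. Compound 4 (`NC1=NC2(CCSCC2)N(OCCCOc2ccc(Cl)cc2)C(N)=N1`) differs from compound 3 as follows: 4-chlorophenyl in place of 2-chlorophenyl on an oxygen on a saturated carbon with 4-chlorophenyl in place of 2-chlorophenyl on an oxygen on a saturated carbon. The closest measured precedent is no change at the digits printed from compound 1 to compound 3 (within the scatter) and it swaps 3-chlorophenyl for 2-chlorophenyl. The steps of no change at the digits printed from compound 1 to compound 2 (within the scatter) and no change at the digits printed from compound 2 to compound 3 (within the scatter) also stay within the scatter. Within the data shown here, no 4-chlorophenyl compound has been measured, so this remains an extrapolation. No change beyond the scatter is expected in this assay in either direction, and the expected step is no change at the digits printed from compound 3 to compound 4 (within the scatter) overall. Compound 4 is estimated at 1 nM with 0.4 nM to 4 nM as the expected range.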

Compound 4, half-maximal inhibitory concentration: 10 nM
Compound 4: middle estimate off by 10-fold (1.00 log units), on the low side; measured number outside the range, above it.
By their numbers in this assay, from the lowest: compounds 1, 2 and 3 (each within the scatter of the next); then compound 4.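

In this assay, among these compounds, 4-chlorophenyl is the first group at this place to go beyond the scatter, giving a 10-fold higher number from compound 3 to compound 4 (1.00 log units; beyond the scatter) and a 10-fold higher number from compound 2 to compound 4 (1.00 log units; beyond the scatter) and also a 10-fold higher number from compound 1 to compound 4 (1.00 log units; beyond the scatter) on the same read-out. Since 2-chlorophenyl and 4-chlorophenyl hold the same atoms joined differently, the arrangement on the phenyl ring matters here, not just its atom content. Nothing given here explains this difference.

From the compounds shown here alone, whether 4-bromophenyl or 4-methoxyphenyl would follow 4-chlorophenyl stays open. So does whether a longer chain to the phenoxy group would alter this step.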